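The source may report more compounds than this note shows. Statements on the series, on what has been measured and on what is new or still open speak of the compounds shown alone.

Going by the values given here, in an ADME assay on a cell-free system (plasma, Rattus norvegicus) for metabolic stability, read by LC-MS, with a stated time of 60 min, tested at 100 uM (a lower number here means that less of the compound is left, a higher number that more of the compound is left), compound 1 (`CCCC(=O)c1ccc(OCCCCOc2cc(C(=O)O)ccc2OC)c(C)c1O`) gives 78% and stands lowest of the two numbers so far. Compound 2 (`Cc1cc(OCCCCOc2ccc(C(=O)CC(C)C)c(O)c2C)ccc1C(=O)O`) gives 101% in the same read-out, a gap beyond the usual scatter. Compound 3 (`COc1ccc(C(=O)O)cc1OCCCCOc1ccc(C(=O)CC(C)C)c(O)c1C`) awaits measurement. The change from compound 1 to compound 3 is methyl in place of hydrogen on a saturated chain carbon bound to two saturated chain carbons in the form of methyl in place of hydrogen on a saturated chain carbon bound to two saturated chain carbons, so propylcarbonyl becomes isobutylcarbonyl. Among the compounds with values here, no measured pair differs in this one place alone. Compound 2 also bears isobutylcarbonyl and gives 101% but differs from compound 1 elsewhere too, which makes it only a weak guide. A small rise, possibly none beyond the scatter, is expected, estimated as a number 8 percentage points higher from compound 1 to compound 3 (within the scatter) in this assay for now. Compound 3 is estimated at 86% with an expected range from 70% to 102% in this read-out.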

Compound 3, percent of the compound remaining: 99%
Compound 3: the middle estimate sits 13 percentage points below what was measured; measured number inside the range.
By their numbers in this assay, from the lowest: compound 1; then compounds 3 and 2 (each within the scatter of the next).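

In this assay, going by these compounds alone, the change from propylcarbonyl to isobutylcarbonyl comes with a number 21 percentage points higher from compound 1 to compound 3 (beyond the scatter), the first reading of this one place on its own. Until now, isobutylcarbonyl had appeared only alongside a difference elsewhere in the structure. In this pair, methyl in place of hydrogen on a saturated chain carbon bound to two saturated chain carbons is therefore enough to shift the percent remaining beyond the scatter, although no measurement at hand explains the step.

On these data alone, the step rests on a single pair, so whether it holds on any other core remains open. Also open, as far as these compounds go, is how a longer chain, a cyclopropylcarbonyl group or an amine in this place would read in this assay.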